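The compounds below may be only part of what the source reports. "The series", "measured", "known", "first", "only" and "open" are said of these compounds alone.

Measured in a functional assay on SW-620 cells (Homo sapiens) for antiproliferative activity, read by MTT assay, with a stated time of 24 h; a lower number here means a stronger inhibitor, a higher number a weaker inhibitor:
Compound 1 `COc1cccc(/C=C/C(=O)c2ccc(OC)c3c2OC(C)(C)C=C3)c1`: > 10000 nM, a limit of the assay
Compound 2 `COc1ccc(C(=O)/C=C/c2ccc([N+](=O)[O-])cc2)c2c1C=CC(C)(C)O2`: 3520 nM
Compound 3 `COc1ccc(C(=O)/C=C/c2cccc([N+](=O)[O-])c2)c2c1C=CC(C)(C)O2`: 4090 nM

Compound 3 stands level with compound 2, the step being a 1.2-fold higher number from compound 2 to compound 3 (0.07 log units; within the scatter), so the two nitro compounds cannot be told apart here. Compound 1 is known only as a limit.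

Compound 4 `COc1ccc(C(=O)/C=C/c2ccsc2)c2c1C=CC(C)(C)O2` keeps the core of compound 3 and changes one group, (thiophen-3-yl in place of 3-nitrophenyl on a double-bonded chain carbon bound to a double-bonded chain carbon). Thiophen-3-yl takes the place of 3-nitrophenyl on a double-bonded chain carbon bound to a double-bonded chain carbon.

Among the measured compounds shown here, no measured compound carries thiophen-3-yl, so the evidence is indirect. The closest guides are the two steps that replace the 3-methoxyphenyl of compound 1 with a nitrophenyl group, an at least 2.8-fold lower number from compound 1 to compound 2 (0.45 log units; beyond the scatter) and an at least 2.4-fold lower number from compound 1 to compound 3 (0.38 log units; beyond the scatter). Both show that the group at this place can shift the number, and that the compound without nitro lies on the weaker side. Compound 4 also has no nitro group, so a small rise in this assay is expected, possibly none beyond the scatter.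

The expected change is a 1.5-fold higher number from compound 3 to compound 4 (0.17 log units; within the scatter). For compound 4 the estimated value is 6000 nM, with an expected range of 2500 nM to 14000 nM.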

Compound 4, half-maximal inhibitory concentration: > 10000 nM
Compound 4 gave a limit, no number (the forecaster's own chance of this, stated with the estimate: 30%); at least 1.6-fold (0.22 log units) between middle value and limit.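

Replacing a nitrophenyl group with thiophen-3-yl on this double-bonded chain carbon is not a neutral change: in this assay there is an at least 2.4-fold higher number from compound 3 to compound 4 (0.38 log units; beyond the scatter), and likewise an at least 2.8-fold higher number from compound 2 to compound 4 (0.45 log units; beyond the scatter). The earlier compounds shown here showed only that 3-methoxyphenyl here lies on the weaker side of the nitrophenyl groups, and compound 4 now shows the same for a five-membered aromatic ring with one hetero atom. Among the compounds shown, only the two nitro compounds give a readable number, while the other two sit together at the limit: the limit of > 10000 nM in this assay, at which 2 of the 4 values shown sit.

As far as these compounds go, how far compound 1 and compound 4 lie past that limit stays unknown, so the step between them cannot be read. Also open, from the compounds shown here alone, is whether an amine or a carboxylic acid in place of the nitro group would keep a readable number.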